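The source may hold more compounds than are shown below. What is called first, only, known or untested is meant among the compounds shown, and "the series" means these compounds.

Measured compounds: compound 1 `COC(=O)CC(=O)N1N=C(c2ccc(N3CCN(C)CC3)cc2)CC1c1ccc(N(C)C)cc1` with -0.4%; compound 2 `CN(C)c1ccc(C2CC(c3ccc(-n4cncn4)cc3)=NN2C(=O)c2cc(Cl)cc(Cl)c2)cc1` with 9.4%.

In a functional assay on MDA-MB-231 cells (Homo sapiens) for inhibition, read by sulforhodamine B assay, tested at 10 uM (on this read-out lower numbers stand for less inhibition and higher numbers for more inhibition at the one concentration tested (going by the name of the read-out)), compound 1 gives -0.4% and compound 2 gives 9.4%. Compound 2 shows the higher of the two numbers, yet its gap to compound 1 lies within the usual scatter, so the two cannot be told apart. Compound 3 `CN(C)c1ccc(C2CC(c3ccc(-n4cncn4)cc3)=NN2S(=O)(=O)c2ccc(C#N)cc2)cc1` differs from compound 2 by (4-cyanophenyl)sulfonyl in place of (3,5-dichlorophenyl)carbonyl on an amine nitrogen in a ring. Within the data shown here, no measured pair bears on this change, so no step beyond the scatter is expected in either direction. In this assay compound 3 is estimated at 8%, between -10% and 30%, an expected step of a number 1.4 percentage points lower from compound 2 to compound 3 (within the scatter).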

Compound 3, a percentage reported as inhibition, at one concentration (the size of the read-out at that concentration, not a potency): 32.8%
The estimate for compound 3 lay 24.8 percentage points below the measured number; the whole stated range lies below it.
By their numbers in this assay, from the lowest: compounds 1 and 2 (each within the scatter of the next); then compound 3.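

In this assay, (4-cyanophenyl)sulfonyl in place of (3,5-dichlorophenyl)carbonyl on the amine nitrogen in a ring gives a number 23.4 percentage points higher from compound 2 to compound 3 (beyond the scatter), the only step beyond the scatter among the compounds shown. It shows that the number at this position on the shared core depends on the group carried there, which the earlier values could not show. Nothing measured here accounts for this step. Going by these compounds, both the linker and the aryl group change at once, so it stays open which of them carries the step. A (4-cyanophenyl)carbonyl group on this nitrogen would separate the two.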